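A few compounds are considered here, and "the series" means these few. Any claim that something is new, unique, unknown or untested is made for them only; others in the source may bear on it.

Measured in an ADME assay, at pH 5; on this read-out higher numbers stand for a longer-lived compound and lower numbers for a shorter-lived compound:
- compound 1 `COc1cnc(C[S+]([O-])c2nc3cc(OCC(F)(F)F)ccc3[nH]2)c(C)c1OC`: 3.3 h
- compound 2 `COc1ccnc(C[S+]([O-])c2nc3cc(OCC(F)(F)F)ccc3[nH]2)c1C`: 0.15 h

Of these two, compound 1 stands higher, at 3.3 h. Compound 3 `COc1cnc(C[S+]([O-])c2nc3cc(OC(F)(F)C(F)F)ccc3[nH]2)c(C)c1OC` keeps the core of compound 1 and differs from it in one place: 1,1,2,2-tetrafluoroethyl in place of 2,2,2-trifluoroethyl on an oxygen on an aromatic ring. Among the compounds with values here, the only measured step, a 22-fold lower number from compound 1 to compound 2 (1.34 log units; beyond the scatter), is large and lies beyond the scatter. However, it comes from hydrogen in place of methoxy on an aromatic carbon, which is a different change. Within the data shown here, it shows that this assay can respond strongly to a single replacement, but no measured step touches the 2,2,2-trifluoroethyl group. With no evidence for a large shift in either direction, little movement in this assay is expected. The estimated step is a 1.2-fold higher number from compound 1 to compound 3 (0.08 log units; within the scatter), which would stay within the scatter. For compound 3 the expected value is 4 h, with an estimated range of 2 h to 8 h.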

Compound 3, half-life: 6.8 h
Estimate against measurement, compound 3: 1.7-fold (0.23 log units) below, within the range that was stated.
By their numbers in this assay, from the lowest: compound 2; then compound 1; then compound 3.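

In this assay, the group on the oxygen now proves able to move the read-out: 1,1,2,2-tetrafluoroethyl in place of 2,2,2-trifluoroethyl gives a 2.1-fold higher number from compound 1 to compound 3 (0.31 log units; beyond the scatter). This modest step is smaller in size than the large one at the other site, a 22-fold lower number from compound 1 to compound 2 (1.34 log units; beyond the scatter), so both places respond, but to different degrees. Nothing available accounts for the shift at the oxygen.

As far as these compounds go, whether the rise follows from the added fluorine or from the different placing of fluorine along the two-carbon chain stays open. Also open, from the compounds shown here alone, are how a plain ethyl group or a longer fluorinated chain such as 2,2,3,3,3-pentafluoropropyl on that oxygen would behave, and whether the same change would carry over to the core of compound 2.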